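The source may report more compounds than this note shows. Statements on the series, on what has been measured and on what is new or still open speak of the compounds shown alone.

Compound 1 `O=C(Nc1ccccn1)c1cccc(Nc2ncc(F)c(Nc3ccc(F)cc3)n2)c1` gives 15100 nM in a functional assay on DU-145 cells (Homo sapiens) for antiproliferative activity, read by sulforhodamine B assay, with a stated time of 3 days (a higher number here means a weaker inhibitor of growth, a lower number a stronger inhibitor of growth), and it is the only one of the three measured compounds that returns a number at all. Compound 2 `O=C(Nc1nccs1)c1cccc(Nc2ncc(F)c(Nc3ccc(F)cc3)n2)c1` reaches only a limit of the assay in this assay, > 10000 nM. Compound 3 `O=C(Nc1cccc(Nc2ncc(F)c(Nc3ccc(F)cc3)n2)c1)c1ccccc1` likewise reaches only a limit in this assay, > 10000 nM. Because the limit of > 10000 nM in this assay, at which 2 of the 3 values shown sit, two of the three values sit at the limit, the steps a step that the limit leaves unreadable from compound 1 to compound 2, a step that the limit leaves unreadable from compound 1 to compound 3 and a step that the two limits leave unreadable from compound 2 to compound 3 cannot be read for size or direction. Compound 4 `O=C(Nc1cc(Cl)cc(Cl)c1)c1cccc(Nc2ncc(F)c(Nc3ccc(F)cc3)n2)c1` is the unmeasured compound; it differs from compound 1 by 3,5-dichlorophenyl in place of pyridin-2-yl on an amide-type nitrogen. Within the data shown here, the one measured step that touches the same amide-type nitrogen, a step that the limit leaves unreadable from compound 1 to compound 2, is itself hidden by the limit, so nothing measured tells how large a step to expect in this assay or in which direction. Compound 1 already sits close to the limit, and a change at the same place gave no readable number for compound 2. Compound 4 is therefore expected to land near compound 1, with the step of a 1.3-fold lower number from compound 1 to compound 4 (0.10 log units; within the scatter) expected to stay within the usual scatter. The estimate for compound 4 is 12000 nM, ranging from 4000 nM to 40000 nM, with a real chance that only a limit is reported.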

Compound 4, concentration for 50% growth inhibition: 17500 nM
The estimate for compound 4 lay 1.5-fold (0.16 log units) below the measured number, and the stated range covers the measured number.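

Among these compounds, at the amide-type nitrogen, this assay now has its only readable step, a 1.2-fold higher number from compound 1 to compound 4 (0.06 log units; within the scatter). This step replaces pyridin-2-yl, a ring with a hetero atom and a hydrogen-bond acceptor, with 3,5-dichlorophenyl, a larger ring of carbon only with chlorine on it and no acceptor, yet the two compounds cannot be told apart in this read-out, so this particular exchange leaves growth inhibition unchanged within the scatter. The other steps that reach compound 4 still cannot be read, and the limit is what hides them: the limit of > 10000 nM in this assay, at which 2 of the 4 values shown sit.

The compounds shown leave open whether a different kind of group on this nitrogen, such as a phenyl ring carrying a dimethylamino group or a carboxylic acid, or a longer alkyl chain in place of the ring, would move the number beyond the scatter in either direction. Also open, going by these compounds, is how compound 2 and compound 3 truly compare with compound 1 and compound 4, as each of those two has only a limit and not a number.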